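A few compounds are considered here, and "the series" means these few. Any claim that something is new, unique, unknown or untested is made for them only; others in the source may bear on it.

In a functional assay on HCT-116 cells (Homo sapiens) for antiproliferative activity, read by CCK-8 assay, with a stated time of 72 h (a lower number here means a stronger inhibitor, a higher number a weaker inhibitor), compound 2 `CC1CCN(c2nc(Cl)nc3c2ncn3Cc2ccc(C(=O)Nc3ccccc3N)cc2)CC1` gives 950 nM and compound 1 `Nc1ccccc1NC(=O)c1ccc(Cn2cnc3c(Nc4ccccc4)nc(Cl)nc32)cc1` gives 1070 nM, so the two stand level within the scatter. Compound 3 `Nc1ccccc1NC(=O)c1ccc(Cn2cnc3c(Nc4cccc(Cl)c4)nc(Cl)nc32)cc1` brings one change from compound 2: (3-chlorophenyl)amino in place of 4-methylpiperidin-1-yl on an aromatic carbon. In short, (3-chlorophenyl)amino stands in place of 4-methylpiperidin-1-yl on an aromatic carbon. For the measured compounds named here, the only measured step at this place is a 1.1-fold lower number from compound 1 to compound 2 (0.05 log units; within the scatter), and it stayed small. Going by the values given here, no measured compound carries the (3-chlorophenyl)amino group, so its chloro group remains untested. The expected step is therefore small, a 1.2-fold lower number from compound 2 to compound 3 (0.07 log units; within the scatter), and none beyond the scatter is expected. For compound 3 the estimated value is 800 nM, with an expected range of 300 nM to 2000 nM.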

Compound 3, half-maximal inhibitory concentration: 2340 nM
Estimate against measurement, compound 3: 2.9-fold (0.47 log units) below; the measured number lies above the stated range.
By their numbers in this assay, from the lowest: compounds 2 and 1 (each within the scatter of the next); then compound 3.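

In this assay, this position gives its first step beyond the scatter: (3-chlorophenyl)amino in place of 4-methylpiperidin-1-yl brings a 2.5-fold higher number from compound 2 to compound 3 (0.39 log units; beyond the scatter), a modest weakening. Chloro in place of hydrogen on the anilino ring brings a 2.2-fold higher number from compound 1 to compound 3 (0.34 log units; beyond the scatter), so a single chloro group shifts the number here, although anilino and 4-methylpiperidin-1-yl stood level. Nothing available explains this rise. Still open, from the compounds shown here alone, is whether chloro behaves alike elsewhere on that ring, and whether a methoxy group there would lower the number instead.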